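The source may report more compounds than this note shows. Statements on the series, on what has been measured and on what is new or still open speak of the compounds shown alone.

Compound 1 `COc1ccccc1-c1ncnn1-c1cc(OC)c(OC)c(OC)c1` is one of three compounds with a number in a functional assay on A549 cells (Homo sapiens) for antiproliferative activity, read by MTT assay, with a stated time of 72 h (a higher number here means a weaker inhibitor, a lower number a stronger inhibitor), and compound 1 gives only a limit there, > 10000 nM. Compound 2 `COc1ccc(-n2ncnc2-c2cc(OC)c(OC)c(OC)c2)cc1` likewise gives only a limit, > 10000 nM, in this assay. Compound 3 `CCOc1ccccc1-c1ncnn1-c1cc(OC)c(OC)c(OC)c1` also reaches only a limit, > 10000 nM. The step that the two limits leave unreadable from compound 1 to compound 3 is thus unreadable, since all three values sit at the limit of > 10000 nM in this assay, at which 3 of the 3 values shown sit. Compound 4 `COc1cc(-n2ncnc2-c2cccc(Cl)c2)cc(OC)c1OC` differs from compound 1 by 3-chlorophenyl in place of 2-methoxyphenyl on an aromatic carbon. No measured pair covers this exchange, so the measured steps give no direction for this assay; the only guide is that every compound shown stops at the limit. Compound 4 is therefore estimated at 15000 nM, within 5000 nM to 50000 nM. The step that the limit leaves unreadable from compound 1 to compound 4 is expected to stay within the scatter, most likely again as a limit.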

Compound 4, half-maximal inhibitory concentration: > 10000 nM
Compound 4 was reported as a limit; the forecaster's own chance of this, stated with the estimate: 75%; the middle value is on the limit's open side.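

Going by these compounds alone, compound 4, like compound 1, gives only a limit in this assay, so no step between the two can be read: the limit of > 10000 nM in this assay, at which 4 of the 4 values shown sit. The compounds shown leave open which change to the shared core, if any, would give a readable value.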